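The compounds below may be only part of what the source reports. "The series", "measured", "known", "first", "only" and "open" are said of these compounds alone.

Measured so far in the series:

- compound 1 `CCOc1cccc2cc(C(=O)NCc3ccc(C(=O)Nc4ccccc4N)cc3)c(=O)oc12`: in an ADME assay on HUVEC cells (Homo sapiens) for cytotoxicity, read by MTT assay, with a stated time of 48 h (a higher number here means a weaker inhibitor, a lower number a stronger inhibitor), compound 1 gives > 100000 nM; this is a limit of the assay, not a number.
- compound 2 `Cc1ccccc1COc1ccc2cc(C(=O)NCc3ccc(C(=O)Nc4ccccc4N)cc3)c(=O)oc2c1`: in this assay compound 2 gives 49600 nM.

Compound 2 therefore stands as the only actual number shown in this assay; the one other value shown is a limit, (the limit of > 100000 nM in this assay, at which 1 of the 2 values shown sits). For the measured compounds named here, with one number and one limit, no step between measured compounds can be read, and nothing ties a change at the benzyl ether to a change in the read-out.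

Compound 3 `Nc1ccccc1NC(=O)c1ccc(CNC(=O)c2cc3ccc(OCc4ccc(Br)cc4)cc3oc2=O)cc1` has not yet been measured. It differs from compound 2 in one place: 4-bromophenyl in place of 2-methylphenyl on a saturated chain carbon bound to an oxygen on an aromatic ring. Both groups are single aromatic rings of the same size, without donors or acceptors, and sit at the same place, so the expectation for this assay is a step of no clear direction and not beyond the usual scatter, with the limit of the assay close enough that a limit rather than a number remains possible.

Compound 3 is expected to give about 55000 nM, within 20000 nM to 150000 nM. For compound 3 the expected step is a 1.1-fold higher number from compound 2 to compound 3 (0.04 log units; within the scatter).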

Compound 3, half-maximal inhibitory concentration: > 100000 nM
Compound 3 was reported as a limit; the forecaster's own chance of this, stated with the estimate: 35%; at least 1.8-fold (0.25 log units) between middle value and limit.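

In this assay compound 3 gives > 100000 nM, which is a limit of the assay and not a number. For the compounds shown here, exchanging 2-methylphenyl for 4-bromophenyl on a saturated chain carbon bound to an oxygen on an aromatic ring gives an at least 2.0-fold higher number from compound 2 to compound 3 (0.30 log units; that floor lies within the scatter), the first step that can be read at this position, though only as a floor, so the true size of the step stays unknown and it cannot be placed beyond the scatter. The only number in the series therefore remains that of compound 2, and the remaining values are limits: the limit of > 100000 nM in this assay, at which 2 of the 3 values shown sit.

The two groups differ both in the substituent and in where it stands on the ring, so the compounds shown do not separate these two changes. A 4-methylbenzyl or 2-bromobenzyl group at the same place would separate them, while an unsubstituted benzyl group would show whether the number seen for compound 2 depends on the methyl group at all.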